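Compound 4: 4-chlorophenyl ketone in place of the primary amide

This account rests on a few compounds, and the source may have more. Where it says the series, first, only, none or still open, it means among the compounds named here.

Compound 1 `CC(C)C[C@H](N)c1cc(C(F)(F)F)ccc1N1CCN(C(=O)CCC(N)=O)CC1` stands at the bottom of the numbers shown: in an assay on HEK293 cells for displacement of a labelled ligand from Melanocortin receptor 4 (Homo sapiens) (a lower number here means a stronger inhibitor, a higher number a weaker inhibitor), compound 1 gives > 10000 nM, which is a limit of the assay and not a number. Compound 2 `COc1ccc(CC(C)C(=O)N2CCN(c3ccc(C(F)(F)F)cc3[C@@H](N)CC(C)C)CC2)cc1` gives 120 nM in this assay, and compound 3 `CC(C)C[C@H](N)c1cc(C(F)(F)F)ccc1N1CCN(C(=O)CNc2ccccc2)CC1` gives 3600 nM. Compound 4 `CC(C)C[C@H](N)c1cc(C(F)(F)F)ccc1N1CCN(C(=O)CCC(=O)c2ccc(Cl)cc2)CC1` differs from compound 1 by 4-chlorophenyl in place of amino on a carbonyl carbon. Among the compounds with values here, two measured steps bear on this, both starting from compound 1 and both altering the group carried by the carbonyl carbon: an at least 83-fold lower number from compound 1 to compound 2 (1.92 log units; beyond the scatter) and an at least 2.7-fold lower number from compound 1 to compound 3 (0.44 log units; beyond the scatter). Both sizes are only lower bounds because compound 1 sits at the limit of > 10000 nM in this assay, at which 1 of the 3 values shown sits. A large step toward lower numbers is therefore expected, an at least 20-fold lower number from compound 1 to compound 4 (1.30 log units; beyond the scatter), and compound 4 is estimated at 500 nM (range 100 nM to 5000 nM).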

Compound 4, inhibition constant: 820 nM
The estimate for compound 4 lay 1.6-fold (0.21 log units) below the measured number; low and high end bracket the measured number.
By their numbers in this assay, from the lowest: compound 2; then compound 4; then compound 3. At a limit, above all of these: compound 1.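

With 4-chlorophenyl in place of amino on a carbonyl carbon, the position gives a large step (an at least 12-fold lower number from compound 1 to compound 4 (1.08 log units; beyond the scatter)), in this assay, so the unbranched chain tolerates a terminal aromatic ring once the primary amide is gone. That step is only a lower bound because compound 1 sits at a limit: the limit of > 10000 nM in this assay, at which 1 of the 4 values shown sits. The ketone chain ranks between the other two side chains (a 4.4-fold lower number from compound 3 to compound 4 (0.64 log units; beyond the scatter); a 6.8-fold higher number from compound 2 to compound 4 (0.83 log units; beyond the scatter)).

On these data alone, it remains open whether the ketone carbonyl or the 4-chlorophenyl ring accounts for the step. A secondary alcohol in place of the ketone, or an unsubstituted phenyl ketone, would separate the two.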